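The source may hold more compounds than are shown below. What is called first, only, known or untested is meant among the compounds shown, and "the series" means these compounds.

In an assay on isolated protein for inhibition of hexokinase-2 (Rattus norvegicus), with a stated time of 6 h, tested at 10 mM (on this read-out lower numbers stand for less inhibition and higher numbers for more inhibition at the one concentration tested (going by the name of the read-out)), compound 1 `O=C(CI)NCCCC(=O)NCCCCCCNc1ncnc2c1ncn2[C@@H]1O[C@H](COP(=O)(O)OP(=O)(O)OP(=O)(O)O)[C@@H](O)[C@H]1O` gives 0%, while compound 2 `CC(=O)NCCCCCCCCNc1ncnc2c1ncn2[C@@H]1O[C@H](COP(=O)(O)OP(=O)(O)OP(=O)(O)O)[C@@H](O)[C@H]1O` gives -12%. Among the measured compounds shown here, compound 2 thus holds the lowest of the two numbers measured so far, and the single step from the other measured compound to it, a number 12 percentage points lower from compound 1 to compound 2 (beyond the scatter), lies beyond the scatter although it is only modest in size.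

Compound 3 `O=C(I)NCC(=O)NCCCCCCNc1ncnc2c1ncn2[C@@H]1O[C@H](COP(=O)(O)OP(=O)(O)OP(=O)(O)O)[C@@H](O)[C@H]1O` has not been measured yet. It differs from compound 2 in one place: a group of 8 heavy atoms (3 carbon, 2 nitrogen, 2 oxygen, 1 iodine; no ring) in place of a group of 6 heavy atoms (4 carbon, 1 nitrogen, 1 oxygen; no ring), on a saturated chain carbon, six bonds along the chain from a nitrogen on an aromatic ring.

For the measured compounds named here, only one measured step bears on this change, a number 12 percentage points lower from compound 1 to compound 2 (beyond the scatter), in which a chain group carrying iodine, two nitrogens and two oxygens gave way to a smaller acetamido-bearing chain group, and the number fell modestly. The present change runs the other way, bringing an iodine-bearing group with two nitrogens and two oxygens back in place of the acetamido group. A small rise is therefore expected, a number 12 percentage points higher from compound 2 to compound 3 (beyond the scatter), roughly undoing the earlier fall. Compound 3 is accordingly estimated to give about 0%, within a range from -15% to 15%.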

Compound 3, a percentage reported as inhibition, at one concentration (the size of the read-out at that concentration, not a potency): 0%
Estimate against measurement, compound 3: no gap at the digits printed; the range from low to high includes it.
By their numbers in this assay, from the lowest: compound 2; then compounds 1 and 3 (each within the scatter of the next).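

In this assay, putting the iodine-bearing group in place of the 2-acetamidoethyl group gives a number 12 percentage points higher from compound 2 to compound 3 (beyond the scatter), so a second iodine-bearing group at this place, six bonds along the chain from a nitrogen on an aromatic ring, also stands apart from the acetamido compound. Changing the size of the iodine-bearing group, on the saturated chain carbon bound to a carbonyl carbon, gives no change at the digits printed from compound 1 to compound 3 (within the scatter), so the smaller group and the larger one cannot be told apart in this assay. No accompanying measurement bears on why the numbers behave this way.

Iodine is not the only difference between the acetamido compound and either iodine-bearing compound, so its own part in these steps stays open, and a matched group carrying chlorine or bromine in place of iodine would address that. Going by these compounds, it also remains open whether a terminal amine, a carboxylic acid or a longer chain at this place would give a clearly higher number than compound 3, which gives 0% at the one concentration tested.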